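Chlorophenyl in place of dimethoxyphenyl on the shared core

The source may report more compounds than this note shows. Statements on the series, on what has been measured and on what is new or still open speak of the compounds shown alone.

Compound 1 `CCOC(=O)c1cnn(-c2nc(-c3cccc(OC)c3OC)c(C#N)c(=O)n2C)c1N` gives 69 ug/mL in a functional assay, with a stated time of 150 min; a higher number here means a weaker inhibitor, a lower number a stronger inhibitor. Compound 2 `Cn1c(NN)nc(-c2cccs2)c(C#N)c1=O` gives 63 ug/mL in this assay, a gap to compound 1 that lies within the scatter, so no order between the two is claimed. Compound 3 `CCOC(=O)c1cnn(-c2nc(-c3ccc(Cl)cc3)c(C#N)c(=O)n2C)c1N` differs from compound 1 in one place: 4-chlorophenyl in place of 2,3-dimethoxyphenyl on an aromatic carbon. Going by the values given here, no measured pair shows this change, so nothing beyond the scatter is expected in either direction. Compound 3 is expected to give about 65 ug/mL, within 30 ug/mL to 140 ug/mL. The step this estimate means, a 1.1-fold lower number from compound 1 to compound 3 (0.03 log units; within the scatter), is expected to stay within the scatter.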

Compound 3, half-maximal inhibitory concentration: 87 ug/mL
For compound 3 the middle estimate is 1.3-fold (0.13 log units) below the measured one; measured number inside the range.
By their numbers in this assay, from the lowest: compounds 2, 1 and 3 (each within the scatter of the next).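

In this assay, 4-chlorophenyl in place of 2,3-dimethoxyphenyl on this aromatic carbon gives a 1.3-fold higher number from compound 1 to compound 3 (0.10 log units; within the scatter). The two aryl groups are therefore not told apart here, even though the entering group has 0 hydrogen-bond acceptors and the leaving group has 2. Nothing available bears on why these two groups read alike.

Still open, going by these compounds, is whether any group at this position moves the number beyond the scatter. A carboxylic acid, a primary amine or a longer alkyl chain in place of the aryl ring would test this.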